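This account rests on a few compounds, and the source may have more. Where it says the series, first, only, none or still open, it means among the compounds named here.

Compound 1 `CN1C(=O)C2(C(C#N)=C(N)Oc3cc4oc(-c5ccccc5)cc(=O)c4c(O)c32)c2cccc(Cl)c21` gives 41400 nM in a functional assay on K562 cells (Homo sapiens) for antiproliferative activity, read by MTT assay, with a stated time of 48 h; on this read-out higher numbers stand for weaker inhibition and lower numbers for stronger inhibition. Compound 2 `Cc1ccc2c(c1)C1(C(=O)N2Cc2ccccc2)C(C#N)=C(N)Oc2cc3oc(-c4ccccc4)cc(=O)c3c(O)c21` reaches only a limit of the assay, > 50000 nM, in this assay. This is the limit of > 50000 nM in this assay, at which 1 of the 2 values shown sits, so for compound 2 no number is known, only that it sits at that limit. Compound 3 `N#CC1=C(N)Oc2cc3oc(-c4ccccc4)cc(=O)c3c(O)c2C12C(=O)N(Cc1ccccc1)c1ccc(Br)cc12` differs from compound 2 by bromo in place of methyl on an aromatic carbon. Within the data shown here, no measured pair shows what such a swap does here, so no step beyond the scatter is expected in this assay in either direction. Compound 3 is expected to give 50000 nM, within 20000 nM to 150000 nM, which means an expected step of a number no higher from compound 2 to compound 3 (the limit leaves the size open).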

Compound 3, half-maximal inhibitory concentration: 36400 nM
For compound 3 the middle estimate is 1.4-fold (0.14 log units) above the measured one; the range from low to high includes it.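

In this assay, bromo in place of methyl on an aromatic carbon gives an at least 1.3-fold lower number from compound 2 to compound 3 (0.13 log units; that floor lies within the scatter). Among these compounds, this is the first view of a change at this position, and compound 3 gives a real number, 36400 nM. The true size of the step stays unknown, and the floor alone shows no change beyond the scatter, because compound 2 carries only a limit: the limit of > 50000 nM in this assay, at which 1 of the 3 values shown sits.

As far as these compounds go, what an amine, a methoxy group or a carboxylic acid on this same aromatic carbon would do remains open.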